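Bromo for methoxy on the sulfonyl aryl ring

The compounds below may be only part of what the source reports. "The series", "measured", "known", "first", "only" and "open" are said of these compounds alone.

Compound 2 `COc1ccc(Nc2nc3ccccc3nc2S(=O)(=O)c2ccc(OC)cc2)cc1` holds the lowest of the two numbers given in a functional assay on PC-3 cells (Homo sapiens) for cytotoxicity, read by MTT assay, with a stated time of 72 h (on this read-out lower numbers stand for stronger inhibition and higher numbers for weaker inhibition), where compound 2 gives 8710 nM. Its neighbour compound 3 `COc1ccc(S(=O)(=O)c2nc3ccccc3nc2Nc2ccc(N)cc2)cc1` gives 9640 nM in this assay, a difference that stays within the scatter, so the two cannot be ranked. Compound 1 `COc1ccc(Nc2nc3ccccc3nc2S(=O)(=O)c2ccc(C)cc2)cc1` reaches only the limit of > 50000 nM in this assay, recorded as the limit of > 50000 nM in this assay, at which 1 of the 3 values shown sits. The step of an at least 5.7-fold lower number from compound 1 to compound 2 (0.75 log units; beyond the scatter) is the only one of the two measured steps that bears on the change now in question, since it also alters the group on the aromatic ring attached to the sulfonyl; the step of a 1.1-fold higher number from compound 2 to compound 3 (0.04 log units; within the scatter) touches the other ring and is within the scatter.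

Compound 4 `COc1ccc(Nc2nc3ccccc3nc2S(=O)(=O)c2ccc(Br)cc2)cc1` differs from compound 2 by bromo in place of methoxy on an aromatic carbon. A bromo substituent, like the methyl of compound 1, brings no hydrogen-bond acceptor to that position, and the step from methyl to methoxy was clearly beyond the scatter, so a move back toward weaker inhibition is expected. Compound 4 is therefore estimated at 25000 nM in this assay, within a range of 8000 nM to 80000 nM. The expected step is a 2.9-fold higher number from compound 2 to compound 4 (0.46 log units; beyond the scatter), with a real chance that only a limit is reported.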

Compound 4, half-maximal inhibitory concentration: 1110 nM
The estimate for compound 4 lay 23-fold (1.35 log units) above the measured number; the whole stated range lies above it.
By their numbers in this assay, from the lowest: compound 4; then compounds 2 and 3 (each within the scatter of the next). At a limit, above all of these: compound 1.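

At this position, the loss of the methoxy oxygen did not weaken inhibition: in this assay, bromo in place of methoxy gives a 7.8-fold lower number from compound 2 to compound 4 (0.89 log units; beyond the scatter). The earlier pair, methyl and methoxy, could be read as favouring a hydrogen-bond acceptor on this ring, but compound 4 goes against that reading, since its bromo brings no such acceptor, and methyl in place of bromo is just as far from being equivalent: the change to bromo gives an at least 45-fold lower number from compound 1 to compound 4 (1.65 log units; beyond the scatter). So two groups without an acceptor sit at opposite ends of the series, and the value of compound 1 remains a limit and not a number: the limit of > 50000 nM in this assay, at which 1 of the 4 values shown sits.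

Nothing shown gives a measured reason for the gain with bromo. As far as these compounds go, whether it is particular to bromine or extends to chloro, fluoro, iodo or trifluoromethyl at this position stays open, as does the effect of an amine or a carboxylic acid there, and whether bromo would keep its gain with the amino group of compound 3 on the other ring.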